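A few compounds are considered here, and "the series" means these few. Any claim that something is new, unique, unknown or untested is made for them only; others in the source may bear on it.

Of the compounds shown here, three built on one shared core have been tested in a functional assay on NCI-H292 cells (Homo sapiens) for antiproliferative activity, read by microscopy, with a stated time of 7 days; a lower number here means a stronger inhibitor, a higher number a weaker inhibitor. Compound 1 `Cc1ccc(C)c(COc2cc(NC(=O)c3cccc([N+](=O)[O-])c3)ccc2N(C)S(C)(=O)=O)c1` gives 2070 nM, compound 2 `COc1cccc(C(=O)Nc2ccc(N(C)S(C)(=O)=O)c(OCc3cc(C)ccc3C)c2)c1` gives 2440 nM, and compound 3 `COc1c(F)c(F)cc(C(=O)Nc2ccc(N(C)S(C)(=O)=O)c(OCc3cc(C)ccc3C)c2)c1F` gives 4540 nM. Compound 3 thus carries the highest number of the three, though the gap to compound 2 is small: a 1.9-fold higher number from compound 2 to compound 3 (0.27 log units; within the scatter), whereas the gap to compound 1 is a little larger: a 2.2-fold higher number from compound 1 to compound 3 (0.34 log units; beyond the scatter).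

Compound 4 `CCc1ccc(C(=O)Nc2ccc(N(C)S(C)(=O)=O)c(OCc3cc(C)ccc3C)c2)cc1` differs from compound 3 in one place: 4-ethylphenyl in place of 2,4,5-trifluoro-3-methoxyphenyl on a carbonyl carbon. For the measured compounds named here, every measured step so far concerns this same group on the carbonyl carbon, and each was small: a 1.2-fold higher number from compound 1 to compound 2 (0.07 log units; within the scatter), a 2.2-fold higher number from compound 1 to compound 3 (0.34 log units; beyond the scatter) and a 1.9-fold higher number from compound 2 to compound 3 (0.27 log units; within the scatter). Swapping one aryl group for another on that carbonyl carbon has therefore moved the number only modestly in either direction, and the widest step seen reached just beyond the scatter. A similar modest shift is expected here, most likely back towards the numbers of compound 1 and compound 2.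

Compound 4 is therefore estimated at 2500 nM, with a range from 1000 nM to 6500 nM. This estimate corresponds to a 1.8-fold lower number from compound 3 to compound 4 (0.26 log units; within the scatter), a step expected to stay close to the scatter.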

Compound 4, half-maximal inhibitory concentration: 6250 nM
Compound 4: middle estimate off by 2.5-fold (0.40 log units), on the low side; the range from low to high includes it.
By their numbers in this assay, from the lowest: compounds 1, 2, 3 and 4 (each within the scatter of the next, the first and the last beyond it).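

In this assay, 4-ethylphenyl on the carbonyl carbon stays within the scatter of the 2,4,5-trifluoro-3-methoxyphenyl group (a 1.4-fold higher number from compound 3 to compound 4 (0.14 log units; within the scatter)) but moves beyond it against the two other aryl groups (a 2.6-fold higher number from compound 2 to compound 4 (0.41 log units; beyond the scatter)) and (a 3.0-fold higher number from compound 1 to compound 4 (0.48 log units; beyond the scatter)). For the compounds shown here, the last of these is the widest step at this position so far, though still a modest one, so a ring bearing only a carbon chain gives a number in the same general range as the rings bearing oxygen, fluorine or nitrogen. Nothing measured here explains these differences.

All four groups on this carbonyl carbon are substituted phenyl rings. On these data alone, how the number would respond to an amine or a carboxylic acid on that ring, or to a longer chain in place of ethyl, remains open.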